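Compound 3 versus compound 4: double bond configuration

The source may report more compounds than this note shows. Statements on the series, on what has been measured and on what is new or still open speak of the compounds shown alone.

Values in a functional assay on MCF7 cells (Homo sapiens) for cytotoxicity, read by MTT assay, with a stated time of 48 h; on this read-out lower numbers stand for stronger inhibition and higher numbers for weaker inhibition:
- compound 1 `CC(=NNC(=S)Nc1ccccc1)c1ccccn1`: 0.18 nM
- compound 2 `C/C(=N/NC(=S)Nc1ccc([N+](=O)[O-])cc1)c1ccccn1`: 52 nM
- compound 3 `C/C(=N/NC(=S)Nc1ccc(F)cc1)c1ccccn1`: 1.2 nM

Compound 3 holds the middle place of the three numbers in this assay. Its value of 1.2 nM is higher than that of compound 1 and lower than that of compound 2, and both gaps lie beyond the scatter.

The next compound to be measured is compound 4 `CC(=NNC(=S)Nc1ccc(F)cc1)c1ccccn1`. The change from compound 3 is the two compounds have the same atoms and bonds; at least one stereo element is drawn with a configuration in one of them and without one in the other: 1 of 1 stereo elements differ; a double bond is drawn Z in compound 3 and without a configuration in compound 4. No group leaves or enters, so the fluoro substituent stays in place.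

Among the compounds with values here, the only measured step between two compounds differing in one place is a 43-fold lower number from compound 2 to compound 3 (1.64 log units; beyond the scatter). That large step comes from exchanging one substituent for another, and no such exchange occurs here. It therefore gives no measure of what a change in the drawing of a double bond does. Within the data shown here, no measured pair in this set isolates that change.

The estimate rests on compound 3 at 1.2 nM, and no step beyond the scatter is expected in this assay. The expected step is no change at the digits printed from compound 3 to compound 4 (within the scatter). Compound 4 is expected at 1.2 nM, with an estimated range of 0.4 nM to 4 nM.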

Compound 4, half-maximal inhibitory concentration: 1.2 nM
Compound 4: middle estimate and measured number agree at the digits printed; measured number inside the range.
By their numbers in this assay, from the lowest: compound 1; then compounds 3 and 4 (each within the scatter of the next); then compound 2.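

In this assay, the way the double bond is drawn makes no readable difference: no change at the digits printed from compound 3 to compound 4 (within the scatter). This pair does not compare two defined geometries, and it cannot show how a defined form on the other side of the double bond would behave, since the comparison rests on this: the fact that one of compounds 3 and 4 is drawn with a defined configuration and the other without, at the place where they differ The result also gives fluoro its first direct comparison with hydrogen on the aromatic carbon, where the earlier step set it only against nitro, and in this assay the exchange of hydrogen for fluoro is not neutral: a 6.7-fold higher number from compound 1 to compound 4 (0.82 log units; beyond the scatter).

On these data alone, it remains open which geometry or mixture of geometries is present in compound 4, and so whether the shared value belongs to a single form. The compounds shown also leave open how a methoxy group, an amine or a carboxylic acid on the same aromatic carbon would stand against hydrogen and fluoro in this read-out.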